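A Fluorophenyl Swap on a Weak Antiproliferative Compound

The source may hold more compounds than are shown below. What is called first, only, known or untested is meant among the compounds shown, and "the series" means these compounds.

Going by the values given here, in a functional assay on MDA-MB-231 cells (Homo sapiens) for antiproliferative activity, read by MTT assay, with a stated time of 24 h (a lower number here means a stronger inhibitor, a higher number a weaker inhibitor), compound 2 `COc1ccc(-c2noc(-c3ccncc3)n2)cc1OC1CCCC1` gives 240000 nM as the only true number so far. Compound 1 `c1ccc(-c2noc(-c3ccncc3)n2)cc1` gives > 1000000 nM as a limit of the assay and not a number. Compound 3 `COc1ccc(-c2noc(Cc3c[nH]c4ccccc34)n2)cc1OC1CCCC1` gives > 1000000 nM as a limit too. The set therefore shows the limit of > 1000000 nM in this assay, at which 2 of the 3 values shown sit, and leaves compound 2 as the single measured reference point.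

The next compound to be tested is compound 4 `COc1ccc(-c2noc(-c3ccc(F)cc3)n2)cc1OC1CCCC1`. It differs from compound 2 by having 4-fluorophenyl in place of pyridin-4-yl on an aromatic carbon of the five-membered aromatic ring with 2 nitrogen and 1 oxygen. Among the compounds with values here, no measured pair of compounds shows this kind of change on its own, so the forecast is cautious. The estimated step is a 1.6-fold lower number from compound 2 to compound 4 (0.20 log units; within the scatter) and is expected to be small, toward stronger inhibition, and perhaps no larger than the usual scatter. Compound 4 is expected to give about 150000 nM in this assay with an estimated range from 30000 nM to 800000 nM around that value.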

Compound 4, half-maximal inhibitory concentration: 55500 nM
Beside the measured number, compound 4's estimate is 2.7-fold (0.43 log units) above it; low and high end bracket the measured number.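

Going by these compounds alone, replacing pyridin-4-yl with 4-fluorophenyl on this aromatic carbon gives a 4.3-fold lower number from compound 2 to compound 4 (0.64 log units; beyond the scatter) in this assay, the first change at this position that can be read as a step. The ring nitrogen of pyridin-4-yl, with its hydrogen-bond acceptor, is therefore not needed for a measurable number here, and a ring of carbon only is tolerated at this position, although compound 4 still gives a high number, 55500 nM. The other steps cannot be read, as compound 2 and compound 4 alone carry true numbers while the rest stand at a limit of the assay: the limit of > 1000000 nM in this assay, at which 2 of the 4 values shown sit.

The compounds shown leave open whether the fluorine or the carbon-only ring accounts for the step. On these data alone, it also remains unknown how another group on this aromatic carbon, such as 4-chlorophenyl or 4-aminophenyl, would change the number.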